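Azole and pyridyl substituents on the fluorinated core: microsomal half-life

This account rests on a few compounds, and the source may have more. Where it says the series, first, only, none or still open, it means among the compounds named here.

Measured so far in an ADME assay on microsomes from liver (Mus musculus) for metabolic stability, read by HPLC, using NADPH, with a stated time of 60 min, tested at 1 uM, in the presence of a further agent that is not named here; on this read-out higher numbers stand for a longer-lived compound and lower numbers for a shorter-lived compound:
- compound 1 `Cc1cc(-n2nccn2)cc(C(=O)NNS(=O)(=O)c2ccccc2)c1F`: 0.0333 h
- compound 2 `Cc1cc(-c2ccccn2)cc(C(=O)NNS(=O)(=O)c2ccccc2)c1F`: 0.0667 h
- compound 3 `CCOc1cc(C)cc(C(=O)NNS(=O)(=O)c2ccccc2F)c1`: < 0.0334 h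

Compound 3 gives only a limit of the assay, < 0.0334 h, and no number. Among the two numbers shown, compound 2 has the higher one, with compound 1 nearest; the step of a 2.0-fold higher number from compound 1 to compound 2 (0.30 log units; within the scatter) lies within the scatter, so the two compounds cannot be told apart on this read-out.

Compound 4 `Cc1cc(-n2cccn2)cc(C(=O)NNS(=O)(=O)c2ccccc2)c1F` has not yet been run. Its change from compound 2 is 1H-pyrazol-1-yl in place of pyridin-2-yl on an aromatic carbon. Among the measured compounds shown here, the only measured step in this region of the molecule is a 2.0-fold higher number from compound 1 to compound 2 (0.30 log units; within the scatter), which exchanged one azole for the pyridin-2-yl group and moved the number within the scatter. Compound 4 returns to a five-membered azole, now 1H-pyrazol-1-yl, so in this assay a step of at most the same size, toward compound 1, is expected: a 1.7-fold lower number from compound 2 to compound 4 (0.22 log units; within the scatter). The estimate for compound 4 in this assay is 0.04 h, with a range from 0.02 h to 0.08 h. A value reported only as a limit is a real possibility because the limit of < 0.0334 h in this assay, at which 1 of the 3 values shown sits, is where one of the three values sits.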

Compound 4, half-life: 0.05 h
The estimate for compound 4 lay 1.3-fold (0.10 log units) below the measured number; the measured number falls inside the stated range.
By their numbers in this assay, from the lowest: compounds 1, 4 and 2 (each within the scatter of the next).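

With compound 4, a third aromatic group has been read on this aromatic carbon, and going from the six-membered pyridin-2-yl ring to a five-membered ring does not separate the compounds in this assay: the step is a 1.3-fold lower number from compound 2 to compound 4 (0.13 log units; within the scatter). The earlier compounds shown here offered no comparison between two five-membered azoles; here, 1H-pyrazol-1-yl in place of 2H-1,2,3-triazol-2-yl gives a 1.5-fold higher number from compound 1 to compound 4 (0.18 log units; within the scatter), so the change in hetero atoms within the five-membered ring does not separate them either. Compounds 1, 2 and 4 therefore lie within the scatter of one another, and no dependence of half-life on the choice among these three groups can be read from them.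

On these data alone, compound 3 stands only as a limit and adds no reading at this position: the limit of < 0.0334 h in this assay, at which 1 of the 4 values shown sits. Whether a group of another kind on this aromatic carbon, such as an amine like morpholin-4-yl or a carboxylic acid, would move the half-life in this assay beyond the scatter remains open, as does the effect of changes elsewhere on the shared core.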